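Two measured anilinopyrimidines and a dicyanophenyl analogue

This account rests on a few compounds, and the source may have more. Where it says the series, first, only, none or still open, it means among the compounds named here.

Measured compounds:
- compound 1, `Cc1ccccc1-c1cc(C)c(Oc2cc(N)nc(Nc3ccc(C#N)cc3)n2)c(C)c1`: 25600 nM
- compound 2, `Cc1cccc(-c2cc(C)c(Oc3cc(N)nc(Nc4ccc(C#N)cc4)n3)c(C)c2)c1`: 27600 nM

Both values come from a toxicity assay on MT4 cells (Homo sapiens) for cytotoxicity, read by MTT assay; on this read-out lower numbers stand for higher toxicity in this test and higher numbers for lower toxicity in this test. Within the data shown here, compound 2 holds the highest of the two numbers, but its only neighbour, compound 1, sits so close that the two cannot be told apart: a 1.1-fold higher number from compound 1 to compound 2 (0.03 log units; within the scatter). That single step swaps one methyl position on the outer phenyl ring and leaves the read-out unchanged within the scatter.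

Compound 3, `Cc1cc(-c2ccc(C#N)c(C#N)c2)cc(C)c1Oc1cc(N)nc(Nc2ccc(C#N)cc2)n1`, is the next compound, not yet measured in this assay. It differs from compound 2 as follows: 3,4-dicyanophenyl in place of 3-methylphenyl on an aromatic carbon. Among the measured compounds shown here, no measured step covers a change of this kind; the only step available, the small move from compound 1 to compound 2, shows that the outer phenyl ring tolerates a minor rearrangement without any shift in the read-out. Because a 1.1-fold higher number from compound 1 to compound 2 (0.03 log units; within the scatter) is flat, the working expectation is that compound 3 stays near compound 2, though a shift in either direction cannot be excluded on this evidence. Compound 3 is therefore expected to give 20000 nM, with a plausible range of 6000 nM to 60000 nM, which corresponds to an estimated step of a 1.4-fold lower number from compound 2 to compound 3 (0.14 log units; within the scatter).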

Compound 3, half-maximal cytotoxic concentration: 17600 nM
Compound 3: the middle estimate sits 1.1-fold (0.06 log units) above what was measured, and the stated range covers the measured number.
By their numbers in this assay, from the lowest: compounds 3, 1 and 2 (each within the scatter of the next).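

In this assay, this position now meets a much larger change than a moved methyl: 3-methylphenyl leaves, 3,4-dicyanophenyl enters with its two nitriles and three more heavy atoms, and the swap gives a 1.6-fold lower number from compound 2 to compound 3 (0.20 log units; within the scatter) as its whole effect. Set against the other methyl isomer, the same ring gives a 1.5-fold lower number from compound 1 to compound 3 (0.16 log units; within the scatter) as its step, so the three compounds cannot be told apart on this read-out, whether the outer phenyl carries one methyl or two nitriles. No measurement shown here offers an explanation for this flat result.

On these data alone, all three compounds keep a substituted phenyl ring at this place, so it remains open what a group of another kind, such as a carboxylic acid, an amine or a longer alkyl chain, would do to the number. As far as these compounds go, it also remains open whether a phenyl ring bearing a single nitrile would fall in the same narrow band, or whether the two nitriles of compound 3 each contribute anything separately.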